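Notes on a methyl step from compound 2 to compound 4

A few compounds are considered here, and "the series" means these few. Any claim that something is new, unique, unknown or untested is made for them only; others in the source may bear on it.

Measured so far:
compound 1 `O=C1CCCCCC1C1CC(=O)N(c2ccccc2)C1=O`: 18400 nM
compound 2 `NS(=O)(=O)c1ccc(N2C(=O)CC(CC(=O)c3ccccc3)C2=O)cc1`: 5290 nM
compound 3 `O=C1CCCCC1C1CC(=O)N(Cc2ccccc2)C1=O`: 36000 nM

In an assay on cells (1-87 tumor cell line) for inhibition of Polyunsaturated fatty acid 5-lipoxygenase (Homo sapiens), with a stated time of 5 min (on this read-out lower numbers stand for stronger inhibition and higher numbers for weaker inhibition), compound 2 gives 5290 nM, the lowest of the three numbers. Compound 1 gives 18400 nM and compound 3 gives 36000 nM; both gaps to compound 2 lie beyond the scatter, so compound 2 is the most potent of the measured set. Among the compounds with values here, no step between two measured compounds that differ in one place is available, so the effect of a single change on this read-out is not known from these data.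

Compound 4 `Cc1ccc(C(=O)CC2CC(=O)N(c3ccc(S(N)(=O)=O)cc3)C2=O)cc1` differs from compound 2 as follows: methyl in place of hydrogen on an aromatic carbon.

Without any measured step of this kind, no step beyond the scatter is expected in this assay; the estimated step of a 1.2-fold lower number from compound 2 to compound 4 (0.07 log units; within the scatter) is small. Compound 4 is expected to give 4500 nM, within the range 1500 nM to 13000 nM.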

Compound 4, half-maximal inhibitory concentration: 860 nM
Estimate against measurement, compound 4: 5.2-fold (0.72 log units) above, outside the stated range (below it).
By their numbers in this assay, from the lowest: compound 4; then compound 2; then compounds 1 and 3 (each within the scatter of the next).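

In this assay the series now has its first step at a single place: methyl in place of hydrogen gives a 6.2-fold lower number from compound 2 to compound 4 (0.79 log units; beyond the scatter) and is thus a step beyond the scatter. Within the data shown here, this shows that the aromatic carbon para to a large group, on the benzoyl part, is sensitive to substitution, which the earlier compounds, differing in more than one place, could not show. Nothing measured here accounts for this step.

Going by these compounds, whether an ethyl group, a methoxy group or a chlorine atom at this place would match methyl remains open. So does whether the same change would hold on the cycloalkanone-bearing compounds.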